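From dimethylcarbamoyl to methoxycarbonyl: compound 4 in view

The source may report more compounds than this note shows. Statements on the series, on what has been measured and on what is new or still open speak of the compounds shown alone.

In an ADME assay on HOS cells (Homo sapiens) for cytotoxicity, read by luminescence and ATP content, with a stated time of 48 h (on this read-out higher numbers stand for lower toxicity in this test and lower numbers for higher toxicity in this test), compound 3 (`CN(C)C(=O)CCc1cnc2c(c1)c(N)c(C(=O)NCc1ccc(F)cc1F)c(=O)n2O`) gives only a limit, > 250000 nM and no number. Compound 2 (`Nc1c(C(=O)NCc2ccc(F)cc2F)c(=O)n(O)c2ncc(CCC(=O)O)cc12`) also gives only a limit, > 250000 nM in the same read-out. Among the measured compounds shown here, compound 1 (`Nc1c(C(=O)NCc2ccc(F)cc2F)c(=O)n(O)c2ncc(CCCCc3ccccc3)cc12`) gives 13000 nM as the only true number so far. Compound 4 (`COC(=O)CCc1cnc2c(c1)c(N)c(C(=O)NCc1ccc(F)cc1F)c(=O)n2O`) has methoxy in place of dimethylamino on a carbonyl carbon. Two large steps bear on this chain: an at least 19-fold higher number from compound 1 to compound 2 (1.28 log units; beyond the scatter) and also an at least 19-fold higher number from compound 1 to compound 3 (1.28 log units; beyond the scatter) with the same replaced group. At the carbonyl carbon itself, a step that the two limits leave unreadable from compound 2 to compound 3 tells nothing about size. Both chain ends there sit at the limit of > 250000 nM in this assay, at which 2 of the 3 values shown sit, so no step beyond the scatter is expected in this assay. The expected result is a number no higher from compound 3 to compound 4 (the limit leaves the size open) in size. For compound 4 the estimate is 250000 nM with an expected range of 90000 nM to 400000 nM in all.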

Compound 4, half-maximal cytotoxic concentration: > 250000 nM
Compound 4 was reported as a limit (the forecaster's own chance of this, stated with the estimate: 60%); the middle value lies on the limit itself.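

In this assay, methoxycarbonyl in place of phenethyl on the saturated chain carbon gives an at least 19-fold higher number from compound 1 to compound 4 (1.28 log units; beyond the scatter), so a third chain end, after carboxy and dimethylcarbamoyl, departs from compound 1 in the same direction. Compound 2, compound 3 and compound 4 all give limits, and the steps among them cannot be read. The series now sits largely at one limit: the limit of > 250000 nM in this assay, at which 3 of the 4 values shown sit.

From the compounds shown here alone, the order among carboxy, dimethylcarbamoyl and methoxycarbonyl stays open. Also open, going by these compounds, is whether a plain alkyl chain or an amine on the same saturated chain carbon would give a true number in this assay.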